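A carboxy group added to compound 1

The source may report more compounds than this note shows. Statements on the series, on what has been measured and on what is new or still open speak of the compounds shown alone.

Going by the values given here, in a functional assay on A549 cells (Homo sapiens) for cytotoxicity, read by MTT assay, with a stated time of 72 h (on this read-out higher numbers stand for weaker inhibition and lower numbers for stronger inhibition), compound 1 `O=C1/C(=C/c2ccccc2)COC/C1=C\c1ccccc1F` gives 17600 nM, the highest of the three numbers so far. Compound 2 `O=C1/C(=C/c2cccc(O)c2)COC/C1=C\c1ccccc1F` gives 7400 nM and compound 3 `O=C1/C(=C/c2ccccc2F)COC/C1=C\c1ccc(Cl)cc1Cl` gives 7900 nM, two values within the scatter of each other. Compound 4 `O=C1/C(=C/c2ccccc2F)COC/C1=C\c1ccccc1C(=O)O` differs from compound 1 as follows: carboxy in place of hydrogen on an aromatic carbon. This puts carboxy in place of hydrogen on an aromatic carbon, ortho to a large group. The nearest case is compound 2, which has hydroxy in place of hydrogen, with a 2.4-fold lower number from compound 1 to compound 2 (0.38 log units; beyond the scatter). Compound 3, from a different change, shows a 2.2-fold lower number from compound 1 to compound 3 (0.35 log units; beyond the scatter). Neither contains a carboxy group, so only a weak guide exists. The expected change is a 1.6-fold lower number from compound 1 to compound 4 (0.20 log units; within the scatter), smaller than either measured step. Compound 4 is expected near 11000 nM, with an estimated range of 4000 nM to 35000 nM.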

Compound 4, half-maximal inhibitory concentration: 27900 nM
Compound 4: middle estimate off by 2.5-fold (0.40 log units), on the low side; measured number inside the range.
By their numbers in this assay, from the lowest: compounds 2 and 3 (each within the scatter of the next); then compounds 1 and 4 (each within the scatter of the next).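

In this assay, carboxy in place of hydrogen on an aromatic carbon gives a 1.6-fold higher number from compound 1 to compound 4 (0.20 log units; within the scatter), so at this position the added group leaves the number within the scatter of compound 1. The steps to compound 2 and compound 3 both lay beyond the scatter, so a new group on the core of compound 1 need not lower the number. No measurement shown accounts for this result. The compounds shown leave open what a methyl ester or an amide would give on the same aromatic carbon.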